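This account rests on a few compounds, and the source may have more. Where it says the series, first, only, none or still open, it means among the compounds named here.

Compound 1 `CCCCC(CC)C(=O)Nc1ccc2ccn(Cc3ccc(C(=O)NS(=O)(=O)c4ccc(F)cc4)cc3OC)c2c1`: in a functional assay (trachea) for antagonist activity, with Cavia porcellus as the target (a higher number here means a more potent compound, by a factor of ten per unit of this negative logarithm, a lower number a less potent compound), compound 1 gives 7.7.
Compound 2 `CCCCC(CC)C(=O)Nc1ccc2ccn(Cc3ccc(C(=O)C(C#N)S(=O)(=O)c4ccccc4)cc3OC)c2c1`: in this assay compound 2 gives 8.1.

Going by the values given here, compound 2 holds the higher of the two numbers measured so far; its nearest neighbour is compound 1, and the step of a number 0.40 log units higher from compound 1 to compound 2 (beyond the scatter) lies beyond the scatter, so compound 2 is the more potent of the pair.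

Compound 3 `CCCCC(CC)C(=O)Nc1ccc2ccn(Cc3ccc(C(=O)C(C(=O)OC)S(=O)(=O)c4ccccc4)cc3OC)c2c1` has not yet been measured. It differs from compound 2 in one place: methoxycarbonyl in place of cyano on a saturated chain carbon bound to a carbonyl carbon and a sulfonyl sulfur.

Among the compounds with values here, only one measured step bears on this change, and only indirectly. The step of a number 0.40 log units higher from compound 1 to compound 2 (beyond the scatter) altered the same region of the molecule, replacing the whole group on the carbonyl carbon, and gave a modest gain. The change to compound 3 is smaller: the sulfonyl and carbonyl are kept, and only the cyano is exchanged for methoxycarbonyl. Within the data shown here, nothing among the measured compounds shows what such an exchange does in this assay, so the safest expectation is no step beyond the scatter in either direction.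

The estimate for compound 3 in this assay is therefore 8, with a range from 7.4 to 8.6. That estimate means an expected step of a number 0.10 log units lower from compound 2 to compound 3 (within the scatter), within the scatter.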

Compound 3, negative logarithm of the antagonist equilibrium constant: 8.5
The estimate for compound 3 lay 0.50 log units below the measured number; the range from low to high includes it.
By their numbers in this assay, from the lowest: compound 1; then compound 2; then compound 3.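

In this assay, exchanging cyano for methoxycarbonyl on a saturated chain carbon bound to a carbonyl carbon and a sulfonyl sulfur gives a number 0.40 log units higher from compound 2 to compound 3 (beyond the scatter), so the group held on this carbon matters to the read-out even when the carbonyl and the sulfonyl stay in place. The earlier pair could not show this, since the step of a number 0.40 log units higher from compound 1 to compound 2 (beyond the scatter) replaced the whole group on the carbonyl carbon and did not separate the contribution of any one part of it. Here a single substituent accounts for the whole difference between the two compounds, and the step is beyond the scatter, though no measured result explains why methoxycarbonyl gives the higher number.

What the compounds shown leave open is how far this trend extends at the same carbon: an ethoxycarbonyl group, a longer alkoxycarbonyl chain, a carboxylic acid or a primary amide could each continue the rise, leave the number unchanged or reverse it. As far as these compounds go, it also remains open whether a plain hydrogen on this carbon, with neither cyano nor methoxycarbonyl, would keep any of the potency seen.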